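A few compounds are considered here, and "the series" means these few. Any claim that something is new, unique, unknown or untested is made for them only; others in the source may bear on it.

Compound 1 `COc1ccc(-n2c(=O)n(Cc3cc4cc(Cl)ccc4n3CCCC#N)c3cnccc32)c(F)c1`: in an ADME assay on HeLa cells (Homo sapiens) for cytotoxicity, read by ATP content, with a stated time of 3 days (on this read-out higher numbers stand for lower toxicity in this test and lower numbers for higher toxicity in this test), compound 1 gives > 50000 nM, a limit of the assay.
Compound 2 `O=c1n(Cc2cc3cnccc3n2CCCCF)c2cnccc2n1C1CC1`: in this assay compound 2 gives > 50000 nM, again a limit.
Compound 3 `N#CCCCn1c(Cn2c(=O)n(C3CC3)c3ccncc32)nc2nc(Cl)ccc21`: in this assay compound 3 gives > 50000 nM, also a limit.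

Compound 1 therefore stands at the ceiling of this assay rather than at a number, because of the limit of > 50000 nM in this assay, at which 3 of the 3 values shown sit. Compound 4 `N#CCCCn1c(Cn2c(=O)n(-c3ccc(OC(F)(F)F)cc3)c3ccncc32)cc2cc(Cl)ccc21` differs from compound 1 in one place: 4-(trifluoromethoxy)phenyl in place of 2-fluoro-4-methoxyphenyl on an aromatic nitrogen. For the measured compounds named here, no step between measured compounds is available, so the expected change in this assay is none beyond the scatter, and the step that the limit leaves unreadable from compound 1 to compound 4 is an estimate only. Compound 4 is expected to give about 60000 nM in this assay, with a range from 20000 nM to 150000 nM, most probably reported again as a limit.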

Compound 4, half-maximal cytotoxic concentration: > 50000 nM
Compound 4 was reported as a limit; the forecaster's own chance of this, stated with the estimate: 80%; the middle value does not contradict the limit.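

Compound 1 and compound 4 both stand at a limit, so no step between them can be read: the limit of > 50000 nM in this assay, at which 4 of the 4 values shown sit.

The compounds shown leave open what any of the four would give as an actual number in this assay.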